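A methoxycarbonyl to ethoxycarbonyl step in growth inhibition

The source may hold more compounds than are shown below. What is called first, only, known or untested is meant among the compounds shown, and "the series" means these compounds.

In a functional assay on A549 cells (Homo sapiens) for antiproliferative activity, read by MTT assay, with a stated time of 48 h (a higher number here means a weaker inhibitor of growth, a lower number a stronger inhibitor of growth), compound 1 (`CCOC(=O)N1N=C(c2ccccc2)CC1c1cc(OC)c(OC)c(OC)c1`) gives 6680 nM and compound 2 (`COC(=O)N1N=C(c2ccc(OC)cc2)CC1c1cc(OC)c(OC)c(OC)c1`) gives 3400 nM. Among the measured compounds shown here, these are the only two numbers available, and they lie within the usual scatter of each other, so compound 2 cannot be told apart from compound 1. Compound 3 (`CCOC(=O)N1N=C(c2ccc(OC)cc2)CC1c1cc(OC)c(OC)c(OC)c1`) arises from compound 2 through a single change, methyl in place of hydrogen on a saturated chain carbon bound to an oxygen next to a carbonyl group, which turns methoxycarbonyl into ethoxycarbonyl. For the measured compounds named here, no measured pair shows this change on its own, so the expectation is a cautious one. In this assay no step beyond the scatter is expected, in either direction, and the estimated step is a 1.2-fold higher number from compound 2 to compound 3 (0.07 log units; within the scatter). For compound 3 the estimated value is 4000 nM, with an expected range of 1800 nM to 9000 nM.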

Compound 3, concentration for 50% growth inhibition: 4690 nM
Beside the measured number, compound 3's estimate is 1.2-fold (0.07 log units) below it, and the stated range covers the measured number.
By their numbers in this assay, from the lowest: compounds 2, 3 and 1 (each within the scatter of the next).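

In this assay, among the compounds shown here, the first measured pair for this change shows a 1.4-fold higher number from compound 2 to compound 3 (0.14 log units; within the scatter) when methoxycarbonyl becomes ethoxycarbonyl, so adding methyl on this saturated chain carbon bound to an oxygen next to a carbonyl group does not separate the two compounds. For the compounds shown here, the same measurement gives a first pair for methoxy in place of hydrogen on an aromatic carbon, with a 1.4-fold lower number from compound 1 to compound 3 (0.15 log units; within the scatter) and again no separation beyond the scatter. No evidence bears on the reason for either result.

The compounds shown cover only the methoxycarbonyl and ethoxycarbonyl groups, so they leave open whether a longer chain, such as butoxycarbonyl, would also stay within the scatter at this position. They also leave open how a carboxylic acid or an amide in place of these groups would read out in this assay on growth inhibition.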